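A few compounds are considered here, and "the series" means these few. Any claim that something is new, unique, unknown or untested is made for them only; others in the source may bear on it.

Within the data shown here, in a physicochemical assay for solubility, read by HPLC, in simulated intestinal fluid, with a stated time of 16 h, at pH 6.5 (on this read-out higher numbers stand for higher solubility and lower numbers for lower solubility), compound 1 `CNC(=O)c1cc(C(=O)N[C@H]2CC[C@H](O)CC2)n([C@@H](C)c2ccc(Cl)cc2)n1` gives 102 ug/mL, the lowest of the two actual numbers so far. Compound 2 `CNC(=O)c1cc(C(=O)NC2CC2)n(Cc2ccccc2)n1` stands clearly higher, at 285 ug/mL. Compound 3 `CNC(=O)c1cc(C(=O)N[C@H]2CC[C@H](OC)CC2)n([C@@H](CO)c2ccccc2)n1` reads > 1000 ug/mL, which is a limit of the assay and not a number. Compound 4 `CC[C@@H](c1ccccc1)n1nc(C(=O)NC)cc1C(=O)N[C@H]1CC[C@H](O)CC1` has not yet been measured. It differs from compound 1 in one place, with 1-phenylpropyl in place of 1-(4-chlorophenyl)ethyl on an aromatic nitrogen. Among the measured compounds shown here, no measured pair shows this change alone, so only a small upward step, within the scatter, is expected in this assay. The expected step is a 1.5-fold higher number from compound 1 to compound 4 (0.17 log units; within the scatter). Compound 4 is expected to give about 150 ug/mL, with an estimated range of 60 ug/mL to 400 ug/mL.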

Compound 4, solubility: > 1000 ug/mL
Compound 4: only a limit was reported; the forecaster's own chance of this, stated with the estimate: 3%; middle value at least 6.6-fold (0.82 log units) away from the limit.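

Moving along this position on the aromatic nitrogen, the swap of 1-(4-chlorophenyl)ethyl for 1-phenylpropyl gives an at least 9.8-fold higher number from compound 1 to compound 4 (0.99 log units; beyond the scatter) in this assay, even though both groups hold 9 heavy atoms and one six-membered aromatic ring. For compound 4, > 1000 ug/mL is a limit of the assay and not a number. The step therefore gives only the smallest possible size of the change: the limit of > 1000 ug/mL in this assay, at which 2 of the 4 values shown sit.

The compounds shown cannot separate the loss of chlorine from the longer chain, as both changes happen together. On these data alone, how an amine or a carboxylic acid on this group would read also remains open.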